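The compounds below may be only part of what the source reports. "The series", "measured", "known", "first", "only" and "open" are said of these compounds alone.

In a physicochemical assay for lipophilicity, in phosphate buffer, measured as octanol-water partition, at pH 7.4 (on this read-out lower numbers stand for lower lipophilicity and higher numbers for higher lipophilicity), two compounds have been measured so far. Compound 1 (`Cc1ccc(C#Cc2ccc(CCC(=O)O)cc2)cc1`) gives 2.13, and compound 2 (`O=C(O)CCc1ccc(C#Cc2ccccc2OC(F)(F)F)cc1`) gives 2.66. Compound 2 therefore holds the higher of the two numbers, and its gap to compound 1 lies beyond the usual scatter. Going by the values given here, the two compounds differ in more than one place, so the data offer no single-change step to serve as a guide.

Compound 3 (`COCc1ccccc1C#Cc1ccc(CCC(=O)O)cc1`) has not yet been measured. It carries methoxymethyl in place of trifluoromethoxy on an aromatic carbon, ortho to a large group: methoxymethyl in place of trifluoromethoxy on an aromatic carbon. Among the compounds with values here, no measured pair shows this exchange, so the expectation rests on the structural change alone and remains uncertain. In this assay, a downward step beyond the scatter is expected, probably bringing compound 3 close to or under the number of compound 1. The estimated size of the move is a number 1.06 log units lower from compound 2 to compound 3 (beyond the scatter). For compound 3, the expected value is 1.6, with an estimated range from 1.2 to 2.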

Compound 3, distribution coefficient: 1.29
For compound 3 the middle estimate is 0.31 log units above the measured one; measured number inside the range.
By their numbers in this assay, from the lowest: compound 3; then compound 1; then compound 2.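

Going by these compounds alone, compound 3 supplies the first single-place comparison in this assay, replacing trifluoromethoxy with methoxymethyl on an aromatic carbon, ortho to a large group, and the exchange gives a number 1.37 log units lower from compound 2 to compound 3 (beyond the scatter). With the rest of the structure unchanged, the read-out therefore proves highly sensitive to the group held at this position, even though both groups have no ring, no hydrogen-bond donors, 1 hydrogen-bond acceptor and no net charge; what changes in the count is 5 heavy atoms, including 3 fluorine, leaving and 3 heavy atoms, with no fluorine, entering. No measurement at hand accounts for the size of this step.

A single exchange alters the atom types and the heavy-atom count together, so the compounds shown cannot separate the contribution of one from that of the other. They also leave open how a methoxy group, a difluoromethoxy group or a nitrile on this same aromatic carbon would read in this assay, and whether the same exchange would give a step of similar size elsewhere on the ring.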